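This account rests on a few compounds, and the source may have more. Where it says the series, first, only, none or still open, it means among the compounds named here.

Measured compounds in a functional assay on RAW264.7 cells (Mus musculus) for inhibition, read by ELISA, with a stated time of 24 h; on this read-out higher numbers stand for an effect only at larger amounts of compound and lower numbers for an effect already at smaller amounts:
compound 1 `CC/C=C\C[C@H]1C(=O)C=C[C@H]1CC(=O)OCCCC` gives 23000 nM
compound 2 `CC/C=C\C[C@H]1C(=O)C=C[C@H]1CC(=O)OCc1ccccc1` gives 20000 nM
compound 3 `CC/C=C\C[C@H]1C(=O)C=C[C@H]1CC(=O)Oc1ccccc1OC` gives 32000 nM

Compound 1 stands second highest of the three numbers; its nearest neighbour is compound 2 and its furthest is compound 3, and both gaps lie within the scatter. Compound 4 `CC/C=C\C[C@H]1C(=O)C=C[C@H]1CC(=O)OCCOCCOCCO` is not yet measured. It differs from compound 1 by 2-(2-hydroxyethoxy)ethoxy in place of ethyl on a saturated chain carbon, two bonds along the chain from an oxygen next to a carbonyl group. Among the measured compounds shown here, the one measured step at the ester side chain, a 1.2-fold lower number from compound 1 to compound 2 (0.06 log units; within the scatter), sits within the scatter, and the three esters so far cluster closely, so the ester substituent appears to matter little here. For the measured compounds named here, no step with a hydroxyl-bearing chain exists, which widens the uncertainty. For compound 4 the expected step is a 1.1-fold higher number from compound 1 to compound 4 (0.04 log units; within the scatter), with no direction beyond the scatter. Compound 4 is therefore estimated at 25000 nM, in the range 10000 nM to 60000 nM.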

Compound 4, half-maximal effective concentration: 42000 nM
Compound 4: the middle estimate sits 1.7-fold (0.23 log units) below what was measured; measured number inside the range.
By their numbers in this assay, from the lowest: compounds 2, 1, 3 and 4 (each within the scatter of the next, the first and the last beyond it).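

Within this assay, 2-(2-hydroxyethoxy)ethoxy in place of ethyl, on a saturated chain carbon two bonds along the chain from an oxygen next to a carbonyl group, gives a 1.8-fold higher number from compound 1 to compound 4 (0.26 log units; within the scatter), so this much larger chain with a hydroxyl brings no change beyond the scatter. Set against phenyl, (2-(2-hydroxyethoxy)ethoxy)methyl gives a 2.1-fold higher number from compound 2 to compound 4 (0.32 log units; beyond the scatter), the only step in the series beyond the scatter. No measured evidence accounts for this step.

Open, as far as these compounds go, is whether the hydroxyl or the chain length carries the step, and whether a terminal amine or carboxylic acid would shift the number.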